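This account rests on a few compounds, and the source may have more. Where it says the series, first, only, none or still open, it means among the compounds named here.

Compound 1 `N#CC1CN1C(=O)Nc1ccc([N+](=O)[O-])cc1` gives 3000 nM in a functional assay on MCF7 cells (Homo sapiens) for inhibition; on this read-out lower numbers stand for stronger inhibition and higher numbers for weaker inhibition.
Compound 2 `N#CC1CN1C(=O)Nc1ccccc1` gives 2900 nM in this assay.
Compound 3 `N#CC1CN1C(=O)Nc1ccc(C(F)(F)F)cc1` gives 1500 nM in this assay.

The three measured compounds share one core and differ only in the group on the aromatic ring. Compound 2 stands second highest of the three numbers in this assay; its nearest neighbour is compound 1 and its furthest is compound 3, yet every one of the steps among them lies within the scatter: a 1.0-fold lower number from compound 1 to compound 2 (0.01 log units; within the scatter), a 2.0-fold lower number from compound 1 to compound 3 (0.30 log units; within the scatter) and a 1.9-fold lower number from compound 2 to compound 3 (0.29 log units; within the scatter).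

Compound 4 `CC(=O)c1cccc(NC(=O)N2CC2C#N)c1` has not yet been measured. It derives from compound 2 by acetyl in place of hydrogen on an aromatic carbon. For the measured compounds named here, the steps that bear on this change are those in which a group on the same aromatic ring was exchanged for hydrogen or for another group, and none of them moved the number beyond the scatter. Nothing here points to a ring substituent that shifts this assay by more than the scatter, so no step beyond the scatter is expected in either direction. Compound 4 is therefore expected to give 2500 nM, with a range from 1000 nM to 6000 nM. This expectation amounts to a 1.2-fold lower number from compound 2 to compound 4 (0.06 log units; within the scatter).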

Compound 4, half-maximal inhibitory concentration: 3600 nM
For compound 4 the middle estimate is 1.4-fold (0.16 log units) below the measured one; low and high end bracket the measured number.
By their numbers in this assay, from the lowest: compounds 3, 2, 1 and 4 (each within the scatter of the next, the first and the last beyond it).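

In this assay, acetyl in place of hydrogen on an aromatic carbon, meta to a group of 8 heavy atoms, gives a 1.2-fold higher number from compound 2 to compound 4 (0.09 log units; within the scatter), so this place on the ring accepts a chain of 3 heavy atoms with a double bond outside the aromatic ring without a step beyond the scatter. The earlier steps exchanged only hydrogen, nitro and trifluoromethyl at a single place on the ring, so compound 4 is the first of the compounds shown to carry a group at this place, and the insensitivity seen so far now extends to a second place and a further kind of group. Nothing measured here bears on why this change leaves the number within the scatter.

The compounds shown leave open whether any group at this place, such as an amine, a carboxylic acid or a longer chain, would move the number beyond the scatter in either direction. They also leave open how acetyl would read at the place held by nitro and trifluoromethyl, since no pair shown separates the group from its position.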